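A few compounds are considered here, and "the series" means these few. Any claim that something is new, unique, unknown or untested is made for them only; others in the source may bear on it.

Compound 1 `O=C(c1ccn(-c2ccc3c(c2)B(O)OC3)c1)c1ccc(Cl)cc1Cl` carries a 2,4-dichlorophenyl group on the carbonyl carbon of a shared core. In an ADME assay on L929 cells (Mus musculus) for cytotoxicity, read by resazurin assay, with a stated time of 72 h (on this read-out lower numbers stand for stronger inhibition and higher numbers for weaker inhibition), compound 1 gives > 10 ug/mL, which is a limit of the assay and not a number. Compound 2 `NCc1ccc(C(=O)c2ccn(-c3ccc4c(c3)B(O)OC4)c2)cc1` has a 4-(aminomethyl)phenyl group in that place. In this assay compound 2 gives > 10 ug/mL, again a limit of the assay rather than a number. The step that the two limits leave unreadable from compound 1 to compound 2 cannot be read, because the limit of > 10 ug/mL in this assay, at which 2 of the 2 values shown sit, and no difference between the two can be seen. Compound 2 therefore stands at that limit, with nothing beyond it known.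

Compound 3 `CCCCCC(=O)c1ccn(-c2ccc3c(c2)B(O)OC3)c1` differs from compound 2 by pentyl in place of 4-(aminomethyl)phenyl on a carbonyl carbon. Among the compounds with values here, no measured step bears on this change, since the only step between measured compounds, from compound 1 to compound 2, has no readable size. The expected step that the limit leaves unreadable from compound 2 to compound 3 is therefore none beyond the scatter, with a further limit the most likely outcome. Compound 3 is expected to give 12 ug/mL in this assay, with a range from 5 ug/mL to 30 ug/mL.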

Compound 3, half-maximal inhibitory concentration: > 10 ug/mL
Compound 3 ended at the assay's limit; the forecaster's own chance of this, stated with the estimate: 70%; the middle value does not contradict the limit.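

No step can be read among compound 1, compound 2 and compound 3, because each result is a limit of the assay and not a number: the limit of > 10 ug/mL in this assay, at which 3 of the 3 values shown sit.

On these data alone, what stays open is whether 2,4-dichlorophenyl, 4-(aminomethyl)phenyl or pentyl on the carbonyl carbon makes any difference in this assay, and how large that difference would be.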